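The source may hold more compounds than are shown below. What is called first, only, known or untested is meant among the compounds shown, and "the series" means these compounds.

Measured so far in an assay on isolated protein for inhibition of protein deacetylase HDAC6 (Homo sapiens), read by fluorescence, with a stated time of 1 h, tested at 20 uM; a higher number here means more inhibition at the concentration tested (going by the name of the read-out), a lower number less inhibition:
- compound 1, `Nc1ccccc1NC(=O)c1ccc(CSC2=N[C@@H](c3cccnc3)CO2)cc1`: 62%
- compound 2, `Nc1ccccc1NC(=O)c1ccc(CNC2=NC(c3ccc(F)cc3)CO2)cc1`: 68%

Two compounds share the core and differ in the group on the five-membered ring and in the link to it. In this assay compound 1 gives 62% and compound 2 gives 68%; the two numbers lie within the scatter of each other, so neither stands apart from the other. For the measured compounds named here, no step between compounds that differ in one place is available, so no direction of change has been measured.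

Compound 3, `Nc1ccccc1NC(=O)c1ccc(CNC2=NC(c3cccc(F)c3)CO2)cc1`, is the next member. Its difference from compound 2 is 3-fluorophenyl in place of 4-fluorophenyl on a saturated ring carbon. The group entering has the same atoms as the group leaving, joined differently, and sits on a saturated ring carbon of the shared five-membered ring.

Going by the values given here, with no measured step to lean on, the change from compound 2 to compound 3 is expected to stay within the scatter, as the step of a number 3 percentage points lower from compound 2 to compound 3 (within the scatter) estimated here shows. Compound 3 is therefore expected to give about 65% in this assay, with a range from 45% to 85%.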

Compound 3, a percentage reported as inhibition, at one concentration (the size of the read-out at that concentration, not a potency): 70%
The estimate for compound 3 lay 5 percentage points below the measured number; measured number inside the range.
By their numbers in this assay, from the lowest: compounds 1, 2 and 3 (each within the scatter of the next).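

Swapping 4-fluorophenyl for 3-fluorophenyl on the saturated ring carbon of the five-membered non-aromatic ring gives, in this assay, a number 2 percentage points higher from compound 2 to compound 3 (within the scatter). For the compounds shown here, this is the first step between compounds that differ in one place, and it shows that the two fluorophenyl isomers cannot be told apart at this position by this single-concentration read-out. Nothing available bears on the reason for this result.

Still open, going by these compounds, is whether this position responds to a larger change of group, such as an unsubstituted phenyl, a 3-methoxyphenyl, a 3-aminophenyl or a 3-carboxyphenyl, since the fluorophenyl isomers span only a swap of the same atoms joined differently. Also open, on these data alone, are whether the link to the five-membered ring matters on its own, which would take a sulfur-linked partner carrying the same 3-fluorophenyl group, and whether a potency read-out would separate compound 2 and compound 3 where a percentage at one concentration does not.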